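The compounds below may be only part of what the source reports. "The series", "measured", "known", "first", "only" and "open" are said of these compounds alone.

Measured compounds:
compound 1, `COc1cc(-c2cc(/C=C/C(=O)c3ccc(N)cc3)[nH]n2)cc(OC)c1OC`, 1640 nM;
compound 2, `COc1ccc(-c2cc(/C=C/C(=O)c3ccc(N)cc3)[nH]n2)cc1OC`, 2370 nM;
compound 3, `COc1cc(C(=O)/C=C/c2cc(-c3cc(OC)c(OC)c(OC)c3)n[nH]2)cc(OC)c1OC`, 1610 nM.

All three were tested in a functional assay on A498 cells (Homo sapiens) for inhibition, read by sulforhodamine B assay, with a stated time of 48 h; on this read-out lower numbers stand for stronger inhibition of growth and higher numbers for weaker inhibition of growth. Compound 1 and compound 2 differ in one place: hydrogen in place of methoxy on an aromatic carbon. That change gave a 1.4-fold higher number from compound 1 to compound 2 (0.16 log units; within the scatter). Compound 3 and compound 1 differ more broadly, and the difference between the two cores is not broken down here; their values in this assay lie within the scatter of each other, as do those of compound 3 and compound 2.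

Compound 4, `COc1ccc(-c2cc(/C=C/C(=O)c3cc(OC)c(OC)c(OC)c3)[nH]n2)cc1OC`, has not yet been measured. It differs from compound 3 by the same change: hydrogen in place of methoxy on an aromatic carbon. Because the earlier step was a 1.4-fold higher number from compound 1 to compound 2 (0.16 log units; within the scatter), a step of similar size, a 1.4-fold higher number from compound 3 to compound 4 (0.14 log units; within the scatter), is expected from compound 3 to compound 4 in this assay. Compound 4 is therefore estimated to give about 2200 nM in this assay, most likely between 1100 nM and 4500 nM.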

Compound 4, concentration for 50% growth inhibition: 1460 nM
Compound 4: the middle estimate sits 1.5-fold (0.18 log units) above what was measured; low and high end bracket the measured number.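

Putting hydrogen in place of methoxy on an aromatic carbon gave a 1.1-fold lower number from compound 3 to compound 4 (0.04 log units; within the scatter) in this assay. Set beside the earlier step, the result on the two cores cannot be told apart: the same change on two cores in this assay, a 1.4-fold higher number (0.16 log units; within the scatter) from compound 1 to compound 2 and a 1.1-fold lower number (0.04 log units; within the scatter) from compound 3 to compound 4, 1.6-fold (0.20 log units) apart, within the scatter of two such steps. This shows that the change moved the number beyond the scatter on neither core, but it does not show a shared effect of fixed size, as both steps could be scatter alone and two cores are few.

As far as these compounds go, it remains open whether a fluorine atom, a carboxylic acid or a longer chain such as ethoxy in place of methoxy would move the number beyond the scatter. From the compounds shown here alone, how the change behaves on other cores also remains open.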